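Butyl for isopropyl: working notes on compounds 2 and 3

A few compounds are considered here, and "the series" means these few. Any claim that something is new, unique, unknown or untested is made for them only; others in the source may bear on it.

Measured in a functional assay on the whole organism for inhibition, with Chlorella vulgaris as the target, read by spectrophotometry, with a stated time of 4 h; on this read-out lower numbers stand for stronger inhibition and higher numbers for weaker inhibition:
- compound 1, `CC(C)(C)c1ncc(C(=O)Nc2cc(O)cc(Cl)c2)nc1Cl`: 99000 nM
- compound 2, `CC(C)c1cnc(C(=O)/C=C/c2ccccc2O)cn1`: 78000 nM

Compound 2 carries the lowest of the two numbers in this assay, but its nearest neighbour, compound 1, differs from it by an amount that sits within the usual scatter of repeated measurements, so no order between compound 1 and compound 2 is claimed. Among the measured compounds shown here, compound 1 and compound 2 also differ in more than one place, and no single-point step between measured compounds exists in this set.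

Compound 3, `CCCCc1cnc(C(=O)/C=C/c2ccccc2O)cn1`, is the next compound. Relative to compound 2 the change is butyl in place of isopropyl on an aromatic carbon. For the measured compounds named here, with no measured step of this kind to lean on, the expectation for the step from compound 2 to compound 3 in this assay is a small one, in no settled direction, and not beyond the scatter: a 1.1-fold lower number from compound 2 to compound 3 (0.05 log units; within the scatter) is the expected step.

On that basis compound 3 is estimated at 70000 nM in this assay, with a range from 30000 nM to 160000 nM.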

Compound 3, half-maximal inhibitory concentration: 147000 nM
Estimate against measurement, compound 3: 2.1-fold (0.32 log units) below, and the stated range covers the measured number.
By their numbers in this assay, from the lowest: compounds 2, 1 and 3 (each within the scatter of the next).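

In this assay, among the compounds shown here, the change of isopropyl to butyl on an aromatic carbon of a six-membered aromatic ring with 2 nitrogen gives the first single-place step in this set, a 1.9-fold higher number from compound 2 to compound 3 (0.28 log units; within the scatter). For the compounds shown here, at this position, then, the one exchange that can be read leaves compound 2 and compound 3 within the scatter of each other, so no order between them is claimed, and the printed step offers no ground for calling butyl better or worse than isopropyl here. No separate measurement bears on this result, so nothing can be said about what lies behind it.

Going by these compounds, a single step within the scatter does not establish a trend with chain length at this position, so whether a longer chain such as octyl, or a shorter one such as methyl, would stay within the scatter of compound 2 remains open. Also open, on these data alone, is whether a group of another kind at this place, such as an amine or a carboxylic acid, would shift the number in this assay beyond the scatter.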